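A few compounds are considered here, and "the series" means these few. Any claim that something is new, unique, unknown or untested is made for them only; others in the source may bear on it.

Three compounds share one bicyclic lactam core and differ only in the aryl group attached to the nitrogen of a triazole ring. Compound 1 `CC1(C)[C@H]2CC[C@]1(C)N(Cc1cn(-c3ccc(Cl)cc3)nn1)C(=O)C2` carries a 4-chlorophenyl group and in a functional assay on PANC-1 cells (Homo sapiens) for inhibition, read by MTT assay, with a stated time of 24 h (on this read-out lower numbers stand for stronger inhibition and higher numbers for weaker inhibition), compound 1 gives 440 nM. Compound 2 `Cc1ccccc1-n1cc(CN2C(=O)C[C@@H]3CC[C@@]2(C)C3(C)C)nn1` carries a 2-methylphenyl group, and in this assay compound 2 gives 250 nM, the second highest number of the three; the change a 1.8-fold lower number from compound 1 to compound 2 (0.25 log units; within the scatter) is within the scatter. Compound 3 `COc1ccccc1-n1cc(CN2C(=O)C[C@@H]3CC[C@@]2(C)C3(C)C)nn1` carries a 2-methoxyphenyl group, and in this assay compound 3 gives 120 nM; the change a 3.7-fold lower number from compound 1 to compound 3 (0.56 log units; beyond the scatter) is modest but beyond the scatter, as is a 2.1-fold lower number from compound 2 to compound 3 (0.32 log units; beyond the scatter).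

Compound 4 `Cc1ccc(-n2cc(CN3C(=O)C[C@@H]4CC[C@@]3(C)C4(C)C)nn2)cc1` has not yet been measured. Relative to compound 2 the change is 4-methylphenyl in place of 2-methylphenyl on an aromatic nitrogen. Among the measured compounds shown here, none of the measured steps tests this exact change: the only compound with a substituent in the 4-position, compound 1, carries chlorine rather than methyl, and its step to compound 2 is within the scatter. On this thin basis a step in this assay from compound 2 to compound 4 of a 1.4-fold higher number from compound 2 to compound 4 (0.15 log units; within the scatter) toward a somewhat higher number is expected, though one within the scatter would not surprise. Compound 4 is estimated at 350 nM, in the range 150 nM to 800 nM.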

Compound 4, half-maximal inhibitory concentration: 270 nM
Beside the measured number, compound 4's estimate is 1.3-fold (0.11 log units) above it, within the range that was stated.
By their numbers in this assay, from the lowest: compound 3; then compounds 2, 4 and 1 (each within the scatter of the next).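

Swapping 2-methylphenyl for 4-methylphenyl, which keeps the same atoms joined differently, gives a 1.1-fold higher number from compound 2 to compound 4 (0.03 log units; within the scatter) in this assay, so for the methyl group in this pair, where it sits on the phenyl ring makes no readable difference. Methyl in place of chloro on an aromatic carbon gives a 1.6-fold lower number from compound 1 to compound 4 (0.21 log units; within the scatter), which is also too small to read, so the 4-methylphenyl and 4-chlorophenyl groups cannot be told apart here. Among the compounds shown here, the only step of the three that can be read is 4-methylphenyl in place of 2-methoxyphenyl, a 2.3-fold higher number from compound 3 to compound 4 (0.35 log units; beyond the scatter), a modest step that leaves compound 3 as the one compound set apart from all the others, now including compound 4.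

Nothing shown offers a reason for any of these steps. Going by these compounds, it remains open whether the lower number of compound 3 would hold for a 4-methoxyphenyl group, with the methoxy group placed differently on the ring, and what an amine, a carboxylic acid or a longer chain such as butyl on the phenyl ring would do.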